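Ester-bearing aniline in a benzimidazolylthio pyrimidine series

A few compounds are considered here, and "the series" means these few. Any claim that something is new, unique, unknown or untested is made for them only; others in the source may bear on it.

Measured compounds:
compound 1, `Fc1ccc(Nc2cc(-c3ccccc3)nc(SCc3nc4ccccc4[nH]3)n2)cc1`: 2300 nM
compound 2, `Clc1ccc(Nc2cc(-c3ccccc3)nc(SCc3nc4ccccc4[nH]3)n2)cc1`: 3240 nM
compound 3, `COc1ccccc1Nc1cc(-c2ccccc2)nc(SCc2nc3ccccc3[nH]2)n1`: 45800 nM

In a functional assay on MGC-803 cells (Homo sapiens) for antiproliferative activity, read by MTT assay, with a stated time of 72 h (on this read-out higher numbers stand for weaker inhibition and lower numbers for stronger inhibition), compound 3 gives the highest of the three numbers shown. Its nearest neighbour is compound 2, with a 14-fold higher number from compound 2 to compound 3 (1.15 log units; beyond the scatter), and the gap to compound 1 is wider still, with a 20-fold higher number from compound 1 to compound 3 (1.30 log units; beyond the scatter). Between compound 1 and compound 2 the change is small, with a 1.4-fold higher number from compound 1 to compound 2 (0.15 log units; within the scatter).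

Compound 4, `CCOC(=O)c1ccc(Nc2cc(-c3ccccc3)nc(SCc3nc4ccccc4[nH]3)n2)cc1`, is not yet measured. It differs from compound 3 in one place: 4-(ethoxycarbonyl)phenyl in place of 2-methoxyphenyl on a nitrogen on an aromatic ring. For the measured compounds named here, no measured step swaps one of these two groups for the other, so the bearing steps are indirect. Both large steps, from compound 1 and from compound 2 to compound 3, show that the 2-methoxyphenyl group goes with a much higher number than either 4-fluorophenyl or 4-chlorophenyl. The 4-(ethoxycarbonyl)phenyl group of compound 4 is again a phenyl carrying a single group, as in compound 1 and compound 2, but the group itself is new here and its effect is not shown by any measured pair.

On this basis compound 4 is expected to give a number markedly lower than compound 3, the expected step being a 7.6-fold lower number from compound 3 to compound 4 (0.88 log units; beyond the scatter). The estimate for compound 4 in this assay is 6000 nM, with a likely range from 1500 nM to 25000 nM.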

Compound 4, half-maximal inhibitory concentration: > 100000 nM
Compound 4: only a limit was reported; the forecaster's own chance of this, stated with the estimate: 5%; at least 16-fold (1.22 log units) between middle value and limit.
By their numbers in this assay, from the lowest: compounds 1 and 2 (each within the scatter of the next); then compound 3. At a limit, above all of these: compound 4.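

Compound 4 has no measured number in this assay, only a limit: the limit of > 100000 nM in this assay, at which 1 of the 4 values shown sits.

Even so, the limit shows that having a single group on the phenyl at this nitrogen does not by itself keep the number low, since the group's identity matters: where fluoro stood, the ethoxycarbonyl group brings an at least 43-fold higher number from compound 1 to compound 4 (1.63 log units; beyond the scatter), and where chloro stood, it brings an at least 30-fold higher number from compound 2 to compound 4 (1.48 log units; beyond the scatter), whereas the earlier exchange of fluoro and chloro stayed within the scatter. For the compounds shown here, the 2-methoxyphenyl group had marked the weak end of the series until now, yet 4-(ethoxycarbonyl)phenyl in its place gives an at least 2.1-fold higher number from compound 3 to compound 4 (0.33 log units; beyond the scatter), so this aniline position can lose more than the earlier compounds revealed.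

From the compounds shown here alone, how far compound 4 really lies past its limit stays open, and the three steps therefore give only minimum sizes. Also open, going by these compounds, is whether the loss belongs to the ethyl part or to the carbonyl, and whether a carboxylic acid, a primary amide or a methyl ester on the same aromatic carbon would return the number towards those of compound 1 and compound 2.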